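The source may report more compounds than this note shows. Statements on the series, on what has been measured and on what is new or still open speak of the compounds shown alone.

Compound 1 `CO[C@@H]1C[C@@H]2[C@H]([C@]1(N)C(=O)O)[C@@]2(F)C(=O)O` carries the shared core and, in an assay on CHO cells for binding affinity to metabotropic glutamate receptor 2 (Rattus norvegicus) (on this read-out lower numbers stand for stronger inhibition and higher numbers for weaker inhibition), compound 1 gives 39.2 nM, the highest number of the three measured compounds. Compound 2 `N[C@]1(C(=O)O)[C@H]2[C@@H](C[C@H]1OCc1cccc(Cl)c1)[C@]2(F)C(=O)O` gives 3.28 nM and compound 3 `N[C@]1(C(=O)O)[C@H]2[C@@H](C[C@H]1OCc1cc(Cl)cc(Cl)c1)[C@]2(F)C(=O)O` gives 5.61 nM. The change that turns compound 1 into compound 4 `N[C@]1(C(=O)O)[C@H]2[C@@H](C[C@H]1OCc1cccs1)[C@]2(F)C(=O)O` is thiophen-2-yl in place of hydrogen on a saturated chain carbon bound to an oxygen on a saturated carbon. The measured steps that bear on it are a 12-fold lower number from compound 1 to compound 2 (1.08 log units; beyond the scatter) and a 7.0-fold lower number from compound 1 to compound 3 (0.84 log units; beyond the scatter), both of which also replace hydrogen on a saturated chain carbon bound to an oxygen on a saturated carbon with a larger group. A lowering of the number beyond the scatter is therefore expected, and the step expected is a 7.1-fold lower number from compound 1 to compound 4 (0.85 log units; beyond the scatter). Compound 4 is estimated to give about 5.5 nM, within a range of 2 nM to 16 nM.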

Compound 4, inhibition constant: 8.79 nM
Estimate against measurement, compound 4: 1.6-fold (0.20 log units) below; measured number inside the range.
By their numbers in this assay, from the lowest: compounds 2, 3 and 4 (each within the scatter of the next, the first and the last beyond it); then compound 1.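

Thiophen-2-yl, a five-membered aromatic ring with a sulfur atom, also lowers the number in this assay, with a 4.5-fold lower number from compound 1 to compound 4 (0.65 log units; beyond the scatter), so at this position the lowering is not limited to chlorinated phenyl groups. The ring swaps give different results: a 1.6-fold higher number from compound 3 to compound 4 (0.20 log units; within the scatter), whereas a 2.7-fold higher number from compound 2 to compound 4 (0.43 log units; beyond the scatter). No measurement here explains these differences. As far as these compounds go, whether a carboxylic acid or an amine in place of thiophen-2-yl, or a longer chain carrying that ring, would keep the number this low remains open.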